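The compounds below may be only part of what the source reports. "The series", "measured", "known", "first", "only" and "open" are said of these compounds alone.

Compound 1 `COc1cc(-c2nnc3n2NC(c2ccco2)C(C(=O)c2cccs2)S3)cc(OC)c1OC` is one of three close relatives that share a core and differ only in the ring attached to a carbonyl carbon. In a functional assay on HepG2 cells (Homo sapiens) for cytotoxicity, read by MTT assay, with a stated time of 48 h (on this read-out higher numbers stand for weaker inhibition and lower numbers for stronger inhibition), compound 1 gives 64100 nM. Compound 2 `COc1ccc(C(=O)C2Sc3nnc(-c4cc(OC)c(OC)c(OC)c4)n3NC2c2cccs2)cc1` gives 68000 nM, and compound 3 `COc1cc(-c2nnc3n2NC(c2ccco2)C(C(=O)c2ccc(F)c(F)c2)S3)cc(OC)c1OC` gives 52400 nM. All three numbers sit close together, so that compound 1 is separated from compound 2 and from compound 3 by gaps that fall inside the usual scatter of repeated measurements, with compound 2 the nearest and compound 3 the furthest.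

Compound 4 `COc1cc(-c2nnc3n2NC(c2ccco2)C(C(=O)c2ccc(C(F)(F)F)cc2)S3)cc(OC)c1OC` is not yet measured. It differs from compound 1 in one place: 4-(trifluoromethyl)phenyl in place of thiophen-2-yl on a carbonyl carbon

Within the data shown here, only one measured step bears directly on this change, the one in which a six-membered carbon ring with fluorine substituents replaced the same thiophen-2-yl on the carbonyl carbon: a 1.2-fold lower number from compound 1 to compound 3 (0.09 log units; within the scatter). That step stayed within the scatter, so the exchange of this ring for a substituted phenyl has so far left the number essentially unchanged. For compound 4 no movement beyond the scatter is therefore expected, and the step of a 1.1-fold lower number from compound 1 to compound 4 (0.03 log units; within the scatter) is estimated to be small. Compound 4 is expected to give about 60000 nM in this assay, with a likely range from 25000 nM to 150000 nM.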

Compound 4, half-maximal inhibitory concentration: > 100000 nM
Compound 4: a limit, no number; the forecaster's own chance of this, stated with the estimate: 15%; at least 1.6-fold (0.22 log units) between middle value and limit.
By their numbers in this assay, from the lowest: compounds 3, 1 and 2 (each within the scatter of the next). At a limit, above all of these: compound 4.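

Compound 4 is the only compound shown that gives no number, because its result is a limit: the limit of > 100000 nM in this assay, at which 1 of the 4 values shown sits. Placed on the carbonyl carbon, the 4-(trifluoromethyl)phenyl group gives an at least 1.5-fold higher number from compound 1 to compound 4 (0.19 log units; that floor lies within the scatter), and set against the 3,4-difluorophenyl group it gives an at least 1.9-fold higher number from compound 3 to compound 4 (0.28 log units; that floor lies within the scatter). Among these compounds, the earlier compounds showed only that one substituted phenyl ring at this place changes the number within the scatter, whereas both new steps have only a floor, so the true size of this change could be small or much larger, and the direction of the floors is towards weaker inhibition.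

On these data alone, how far the number of compound 4 really lies beyond the limit stays unknown, so this change cannot yet be ranked by size against the step to the 3,4-difluorophenyl group. As far as these compounds go, it also remains open whether the ring itself or the trifluoromethyl group on it decides the result, and whether an amine or a carboxylic acid in place of the trifluoromethyl group would bring the read-out back to a measurable number.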